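The source may hold more compounds than are shown below. What is called first, only, known or untested is meant among the compounds shown, and "the series" means these compounds.

Among the measured compounds shown here, the two compounds with numbers so far are compound 1 `COc1cc(O)c(C(=O)c2ccccc2Br)c(OC)c1` and compound 2 `COc1cc(OC)c(C(=O)c2cccc(Cl)c2)c(O)c1CN1CCCC1`. In a functional assay on THP-1 cells (Homo sapiens) for inhibition, read by ELISA, with stated times of 30 min and 24 h, tested at 1 uM (on this read-out lower numbers stand for a weaker effect and higher numbers for a stronger effect at the one concentration tested), compound 1 gives 7%, while in this assay compound 2 gives 41%. Compound 2 thus stands at the higher of the two numbers, and the nearest number, that of compound 1, lies lower by more than the usual scatter of this assay.

Compound 3 `COc1cc(OC)c(C(=O)c2ccccc2Br)c(O)c1CN1CCCC1` has not yet been measured. It differs from compound 2 in one place: 2-bromophenyl in place of 3-chlorophenyl on a carbonyl carbon. For the measured compounds named here, no step between two measured compounds is known for this change, so its size can only be estimated. Going by the values given here, compound 1 also carries the 2-bromophenyl, yet its core is not the shared core of compound 2 and compound 3, so its low reading shows only that this ring appears in a weak compound and does not measure the step itself. The expectation is that the step of a number 15 percentage points lower from compound 2 to compound 3 (beyond the scatter) will be a moderate fall in this assay, though it could stay within the scatter. On that basis compound 3 is estimated at 26%, expected to lie between 8% and 45%.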

Compound 3, a percentage reported as activity, at one concentration (the size of the read-out at that concentration, not a potency): 19%
Compound 3: the middle estimate sits 7 percentage points above what was measured; the measured number falls inside the stated range.
By their numbers in this assay, from the lowest: compound 1; then compound 3; then compound 2.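

In this assay the exchange of 3-chlorophenyl for 2-bromophenyl on a carbonyl carbon gives a number 22 percentage points lower from compound 2 to compound 3 (beyond the scatter) and so now has a measured size on the shared core, which shows that the number responds to the ring at this position. Compound 3 also ties compound 1 to that core: (pyrrolidin-1-yl)methyl in place of hydrogen on an aromatic carbon gives a number 12 percentage points higher from compound 1 to compound 3 (beyond the scatter) with the 2-bromophenyl unchanged, so this ring no longer has to be read only from the low number of compound 1. No measurement at hand explains either step.

The ring change alters both the halogen and its place on the ring, and a 3-bromophenyl or a 2-chlorophenyl on the shared core would be needed to tell these two apart. The compounds shown also leave open whether the rise belongs to the pyrrolidine itself or would also come with another amine, such as a morpholin-4-ylmethyl or a dimethylaminomethyl group, and whether it would be the same with the 3-chlorophenyl ring in place.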